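A few compounds are considered here, and "the series" means these few. Any claim that something is new, unique, unknown or untested is made for them only; others in the source may bear on it.

Measured so far in a functional assay on NUGC-3 cells (Homo sapiens) for antiproliferative activity, read by sulforhodamine B assay; a lower number here means a stronger inhibitor of growth, a higher number a weaker inhibitor of growth:
- compound 1 `CC(C)CCCOc1cccc(O)c1C(=O)/C=C/c1ccc(O)cc1`: 3520 nM
- compound 2 `CCCCCCOc1cccc(O)c1C(=O)/C=C/c1ccc(O)cc1`: > 30000 nM

Compound 2 gives > 30000 nM, which is a limit of the assay and not a number. Its place in the series is the limit of > 30000 nM in this assay, at which 1 of the 2 values shown sits.

Compound 3 `CC(C)(C)CCOc1cccc(O)c1C(=O)/C=C/c1ccc(O)cc1` has the same atoms as compound 2, joined differently: tert-butyl in place of butyl on a saturated chain carbon, two bonds along the chain from an oxygen on an aromatic ring. Cut one bond further out, this is hexyloxy to 3,3-dimethylbutoxy.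

For the measured compounds named here, only one measured step bears on this change: an at least 8.5-fold higher number from compound 1 to compound 2 (0.93 log units; beyond the scatter). There, propyl replaces isopropyl at a different place on the chain, and the number in this assay rises. Read in reverse, that single pair links a branched chain end with the lower number. Compound 3 also ends in a branched group, though tert-butyl is not isopropyl, so the comparison is only partial. A move to a lower number is therefore expected, of a size similar to the step from compound 1 to compound 2, but a reading at the assay limit remains possible.

The expected change is an at least 5.0-fold lower number from compound 2 to compound 3 (0.69 log units; beyond the scatter), an estimate that rests on this one pair. For compound 3 the estimated value is 6000 nM, with an expected range of 1500 nM to 25000 nM.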

Compound 3, concentration for 50% growth inhibition: 3300 nM
For compound 3 the middle estimate is 1.8-fold (0.26 log units) above the measured one; the measured number falls inside the stated range.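

In this assay, for the compounds shown here, tert-butyl in place of butyl on a saturated chain carbon, two bonds along the chain from an oxygen on an aromatic ring, gives an at least 9.0-fold lower number from compound 2 to compound 3 (0.95 log units; beyond the scatter), which adds a second branched chain end to the single pair available before. Compound 2 is a limit of the assay and not a number, so the size of this step is only a bound: the limit of > 30000 nM in this assay, at which 1 of the 3 values shown sits. The two branched chain ends do not separate from each other, with tert-butyl in place of isobutyl at the same place giving a 1.1-fold lower number from compound 1 to compound 3 (0.03 log units; within the scatter), so in these three compounds the unbranched hexyloxy chain of compound 2 alone stands apart.

Compounds 1 and 3 differ from compound 2 in chain shape only, and these three compounds cannot show how far that reading extends to a longer branched chain or to a chain closed into a cyclohexyl ring. On these data alone, whether a chain ending in an amine or a carboxylic acid would read with the branched chains or with compound 2 also remains open.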